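The source may hold more compounds than are shown below. What is called first, only, known or untested is meant among the compounds shown, and "the series" means these compounds.

The shared core of this small series is carried by compound 1 `COc1cc(C)cc(-c2c(-c3ccnc(-c4ccc(C(C)=O)cc4)c3)cnn2CC#N)c1`, a compound in which a nitrile-bearing chain sits on the pyrazole and an acetyl group stands at the far end of the molecule. In a functional assay on DU-145 cells (Homo sapiens) for cytotoxicity, read by sulforhodamine B assay, with a stated time of 48 h, tested at 100 nM (on this read-out higher numbers stand for a weaker effect at the one concentration tested and lower numbers for a stronger effect), compound 1 gives 89%. Two companions were measured alongside it. Compound 2 `COc1cc(C)cc(-c2nn(CC#N)cc2-c2ccc(-c3cccc(C(C)=O)c3)nc2)c1` gives 87% in this assay, and compound 3 `Cc1cc(O)cc(-c2nn(CC#N)cc2-c2ccnc(-c3ccc(Oc4ccccc4)cc3)c2)c1` gives 86%. The three numbers sit so close together that the gaps between them fall within the usual scatter of repeated measurements, so compound 1 cannot be set apart from the other two on these data; all three show only a weak effect at the single concentration tested.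

The next compound, compound 4 `COc1cc(C)cc(-c2c(-c3ccnc(-c4ccc(N(C)C)cc4)c3)cnn2CC#N)c1`, is compound 1 with one change: dimethylamino in place of acetyl on an aromatic carbon. Among the measured compounds shown here, no pair of measured compounds shows what this particular change does in this assay, so there is no measured step to lean on. With nothing pointing either way, the expectation is that compound 4 behaves much like compound 1, and the step of a number 2 percentage points lower from compound 1 to compound 4 (within the scatter) is expected to stay within the scatter. Compound 4 is therefore estimated to give about 87% in this assay, with a plausible range from 72% to 100%.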

Compound 4, a percentage reported as activity, at one concentration (the size of the read-out at that concentration, not a potency): -51%
Beside the measured number, compound 4's estimate is 138 percentage points above it, and the stated range ends above it.
By their numbers in this assay, from the lowest: compound 4; then compounds 3, 2 and 1 (each within the scatter of the next).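

Replacing acetyl with dimethylamino on the six-membered aromatic ring of carbon brings a number 140 percentage points lower from compound 1 to compound 4 (beyond the scatter) in this assay, so this single place can decide whether a compound has a weak or a strong effect at the one concentration tested. Compounds 1, 2 and 3 could not show this: they differ from one another in more than one place, and their values all lie within the scatter of each other. The two groups have the same count of 3 heavy atoms, and each has 1 hydrogen-bond acceptor and no net charge, so these counts do not separate them, and nothing measured here explains the size of the step.

As far as these compounds go, it remains open whether the strong effect belongs to dimethylamino alone or also appears with a plain amino group, a ring amine such as morpholine, or a methoxy group in the same place. From the compounds shown here alone, it is also open whether the same swap would have a similar effect on compound 2, which carries its acetyl on a differently arranged framework.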